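Methoxy in place of methyl on the shared core

The source may hold more compounds than are shown below. What is called first, only, known or untested is meant among the compounds shown, and "the series" means these compounds.

In an ADME assay on microsomes from liver (Rattus norvegicus) for metabolic stability, read by LC-MS, using NADPH, with a stated time of 30 min, tested at 1 uM (a lower number here means slower removal, a higher number faster removal of the compound), compound 1 (`CC#Cc1cncc(-c2ccc3c(c2)[C@@]2(COC(N)=N2)c2cc(-c4ccnc(F)c4)ncc2O3)c1`) gives 20 mL.min-1.g-1. Compound 2 (`Cc1cc2c(cn1)Oc1ccc(NC(=O)c3ccc(Cl)cn3)cc1[C@@]21COC(N)=N1`) has no exact number, and its result is a limit of the assay: compound 2 reads < 14 mL.min-1.g-1. Compound 3 (`COc1cc2c(cn1)Oc1ccc(NC(=O)c3ccc(Cl)cn3)cc1[C@@]21COC(N)=N1`) differs from compound 2 in one place, with methoxy in place of methyl on an aromatic carbon, next to the ring nitrogen (methoxy in place of methyl on an aromatic carbon). For the measured compounds named here, no measured pair shows this change, so the expectation in this assay is uncertain: a small upward move, not far beyond the usual scatter, or none beyond it. The expected change is a step of a number no lower from compound 2 to compound 3 (the limit leaves the size open). For compound 3 the estimated value is 14 mL.min-1.g-1, with an expected range of 8 mL.min-1.g-1 to 30 mL.min-1.g-1. A result given only as a limit remains quite possible.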

Compound 3, intrinsic clearance in microsomes: < 14 mL.min-1.g-1
Compound 3 gave a limit, no number; the forecaster's own chance of this, stated with the estimate: 50%; the middle value sits exactly at the limit.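

Compound 2 and compound 3 both read as limits, not numbers, so no step between them can be read in this assay: the limit of < 14 mL.min-1.g-1 in this assay, at which 2 of the 3 values shown sit.

The compounds shown leave open whether methoxy in place of methyl on an aromatic carbon moves the read-out in this assay at all, and in which direction.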